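From pentan-3-yl to isobutyl on the shared core

The source may hold more compounds than are shown below. What is called first, only, known or untested is meant among the compounds shown, and "the series" means these compounds.

Within the data shown here, in an ADME assay on HepG2 cells (Homo sapiens) for cytotoxicity, read by MTT assay, with a stated time of 72 h (a higher number here means that more compound is tolerated, a lower number that less compound is tolerated), compound 2 `CCC(CC)Nc1nc2cc(-c3ccc(C)cc3)sc2c(=O)[nH]1` gives 101000 nM as the higher of the two numbers known so far, while compound 1 `CCCCCNc1nc2cc(-c3ccc(C)cc3)sc2c(=O)[nH]1` gives 4200 nM on the same core. Compound 3 `Cc1ccc(-c2cc3nc(NCC(C)C)[nH]c(=O)c3s2)cc1` has not yet been measured. Its change from compound 2 is isobutyl in place of pentan-3-yl on a nitrogen on an aromatic ring and nothing else in the structure differs. Among the measured compounds shown here, only one measured step bears on this, namely a 24-fold higher number from compound 1 to compound 2 (1.38 log units; beyond the scatter) with pentan-3-yl in place of pentyl at that same place. Isobutyl matches neither group, no isobutyl compound has been measured, and two compounds make no trend, so this large step serves only as a rough guide. A move towards a lower number is expected, taking back part of that rise but not all of it. The expected step is a 5.1-fold lower number from compound 2 to compound 3 (0.70 log units; beyond the scatter) on this estimate. For compound 3 the estimated value is 20000 nM with an expected range from 6000 nM to 70000 nM in this assay once it is measured.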

Compound 3, half-maximal cytotoxic concentration: 21600 nM
Estimate against measurement, compound 3: 1.1-fold (0.03 log units) below, and the stated range covers the measured number.
By their numbers in this assay, from the lowest: compound 1; then compound 3; then compound 2.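

In this assay the isobutyl chain settles at a level of its own on the shared core, with a 4.7-fold lower number from compound 2 to compound 3 (0.67 log units; beyond the scatter) on one side and a 5.1-fold higher number from compound 1 to compound 3 (0.71 log units; beyond the scatter) on the other, both of them larger than the usual scatter. This position therefore separates three chains into three distinct levels, and the tolerated concentration does not simply switch between a low and a high value as the first pair alone might have suggested. Branching as such does not carry the whole of the earlier rise, since isobutyl and pentan-3-yl are both branched and still lie apart, with the isobutyl compound closer in size of step to neither extreme by any margin the three numbers can settle; nothing given here accounts for these differences.

The three compounds leave open how a ring at this nitrogen, such as cyclopentyl or cyclohexyl, or a chain ending in a hydroxyl group or an amine would compare with these purely carbon chains. They also leave open whether a shorter branched group such as isopropyl would continue the order seen here.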